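The compounds below may be only part of what the source reports. "The series", "measured", "known", "first", "only" and "open" are said of these compounds alone.

Values measured in a functional assay on HT-29 cells (Homo sapiens) for cytotoxicity, read by MTT assay, with a stated time of 72 h; a higher number here means a weaker inhibitor, a lower number a stronger inhibitor:

- compound 1 `COc1ccc(NC(=O)CN2CCN(c3nnc(Cc4ccncc4)c4ccccc34)CC2)cc1OC`: 40100 nM
- compound 2 `Cc1ccc(NC(=O)CN2CCN(c3nnc(Cc4ccncc4)c4ccccc34)CC2)c(C)c1`: 1930 nM
- compound 3 `O=C(CN1CCN(c2nnc(Cc3ccncc3)c3ccccc23)CC1)Nc1cccc(Br)c1`: 1350 nM

Compound 3 cannot be told apart from compound 2, with a 1.4-fold lower number from compound 2 to compound 3 (0.16 log units; within the scatter). The two sit well under compound 1, with a 21-fold lower number from compound 1 to compound 2 (1.32 log units; beyond the scatter) and a 30-fold lower number from compound 1 to compound 3 (1.47 log units; beyond the scatter).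

The unmeasured compound 4 `O=C(CN1CCN(c2nnc(Cc3ccncc3)c3ccccc23)CC1)Nc1ccc(Br)cc1` carries 4-bromophenyl in place of 3-bromophenyl on an amide-type nitrogen. Within the data shown here, no measured pair isolates this exact change. The two large steps show that the group on this nitrogen can matter, but both start from 3,4-dimethoxyphenyl, which is a different replacement. The closest guide is the swap of 2,4-dimethylphenyl for 3-bromophenyl, which gave a 1.4-fold lower number from compound 2 to compound 3 (0.16 log units; within the scatter).

From the compounds shown here alone, on that basis, no step beyond the scatter is expected in this assay, and the direction remains open, so the range is kept wide. The estimated change is a 1.3-fold higher number from compound 3 to compound 4 (0.10 log units; within the scatter). For compound 4 the expected value is 1700 nM, within an estimated range of 600 nM to 6000 nM.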

Compound 4, half-maximal inhibitory concentration: 1990 nM
Estimate against measurement, compound 4: 1.2-fold (0.07 log units) below; the range from low to high includes it.
By their numbers in this assay, from the lowest: compounds 3, 2 and 4 (each within the scatter of the next); then compound 1.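

Exchanging 3-bromophenyl for 4-bromophenyl on the amide-type nitrogen, with the same atoms joined differently, gives a 1.5-fold higher number from compound 3 to compound 4 (0.17 log units; within the scatter) in this assay, so this change of bromine placement cannot be distinguished from repeat-measurement noise. The 2,4-dimethylphenyl group also cannot be told apart from 4-bromophenyl, with a 1.0-fold higher number from compound 2 to compound 4 (0.01 log units; within the scatter), whereas 3,4-dimethoxyphenyl stays clearly separate, with a 20-fold lower number from compound 1 to compound 4 (1.30 log units; beyond the scatter). Nothing available here explains why these groups read as they do.

The compounds shown leave open whether a single methoxy group, as in 4-methoxyphenyl, or an unsubstituted phenyl would read with the bromophenyl compounds or with compound 1. They also leave open how a carboxylic acid or an amine on the phenyl ring would read in this assay.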